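Acetyl Exchanged for Acetoxy on a Shared Core

This account rests on a few compounds, and the source may have more. Where it says the series, first, only, none or still open, it means among the compounds named here.

Going by the values given here, compound 1 `CC(=O)c1ccc2c(c1)C(n1ccccc1=O)=CC(C)(C)O2` is the most potent of the three compounds measured so far in a functional assay (aorta) with Rattus norvegicus as the target (on this read-out higher numbers stand for higher potency (the scale is a negative logarithm) and lower numbers for lower potency), where compound 1 gives 7.37. Compound 2 `CCC(=O)c1ccc2c(c1)C(n1ccccc1=O)=CC(C)(C)O2` carries a propanoyl group where compound 1 carries acetyl; in this assay compound 2 gives 6.63, so that a number 0.74 log units lower from compound 1 to compound 2 (beyond the scatter). Compound 3 `CC1(C)C=C(n2ccccc2=O)c2cc(O)ccc2O1` carries hydroxy in that place, and in this assay compound 3 gives 5.44; the step of a number 1.93 log units lower from compound 1 to compound 3 (beyond the scatter) is large, and a number 1.19 log units lower from compound 2 to compound 3 (beyond the scatter) as well.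

Compound 4 `CC(=O)Oc1ccc2c(c1)C(n1ccccc1=O)=CC(C)(C)O2` has not yet been measured. It differs from compound 1 in a single place: acetoxy in place of acetyl on an aromatic carbon. Among the compounds with values here, no measured step reproduces this change exactly. The step that bears most on it runs from compound 1 to compound 3, where acetyl gave way to hydroxy and the number fell by a number 1.93 log units lower from compound 1 to compound 3 (beyond the scatter); acetoxy, like hydroxy, joins the aromatic carbon through an oxygen. The smaller step of a number 0.74 log units lower from compound 1 to compound 2 (beyond the scatter) shows that even a change kept within the acetyl group already cost something. Taken together, a clear fall in this assay is expected, though smaller than the drop to compound 3, since the carbonyl is retained. Compound 4 is therefore estimated to give 6.3 in this assay, within a range of 5.4 to 7.2; this estimate corresponds to an expected step of a number 1.07 log units lower from compound 1 to compound 4 (beyond the scatter).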

Compound 4, logarithm of the reciprocal of the active concentration, log(1/C): 5.6
Compound 4: middle estimate off by 0.70 log units, on the high side; the range from low to high includes it.
By their numbers in this assay, from the lowest: compounds 3 and 4 (each within the scatter of the next); then compound 2; then compound 1.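

In this assay, acetoxy in place of acetyl on this aromatic carbon gave a number 1.77 log units lower from compound 1 to compound 4 (beyond the scatter), so a carbonyl in the entering group did not keep the number of compound 1. The exchange of propanoyl for acetoxy gave a number 1.03 log units lower from compound 2 to compound 4 (beyond the scatter), which shows that the fall is not confined to one acyl group: compound 1 and compound 2, whose carbonyl carbon is bound directly to the aromatic carbon, both stand clear of compound 4. Acetyl in place of hydrogen on the oxygen gave a number 0.16 log units higher from compound 3 to compound 4 (within the scatter), so hydroxy and acetoxy cannot be told apart on this read-out, and among these four compounds every group joined through an oxygen goes with the low numbers, with none going against this.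

The data shown give no reason for these numbers. As far as these compounds go, how a methoxy group or an amine on this aromatic carbon would read remains open, as does whether a longer chain on the acetoxy carbonyl would shift the number of compound 4.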